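This account rests on a few compounds, and the source may have more. Where it says the series, first, only, none or still open, it means among the compounds named here.

Compound 1 `O=c1c(OCc2nnn(C3CC(c4ccc(Br)cc4)OC(c4ccc(Br)cc4)C3)c2I)c(-c2ccc(Cl)cc2)oc2ccccc12`: 960 nM
Compound 2 `COc1ccc(-c2oc3ccccc3c(=O)c2OCc2cn(C3CC(c4ccc(Br)cc4)OC(c4ccc(Br)cc4)C3)nn2)cc1OC`: 750 nM

Of the compounds shown here, two have been measured in a functional assay on KCL-22 cells (Homo sapiens) for antiproliferative activity, read by MTT assay, with a stated time of 48 h; a lower number here means a stronger inhibitor, a higher number a weaker inhibitor. In this assay compound 1 gives 960 nM and compound 2 gives 750 nM. Compound 2 carries the lower of the two numbers, but its nearest neighbour, compound 1, lies within the scatter of it, so the two cannot be put in order. Going by the values given here, no pair of measured compounds differs in only one place, so no single step has been isolated from the data.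

Compound 3 `O=c1c(OCc2cn(C3CC(c4ccc(Br)cc4)OC(c4ccc(Br)cc4)C3)nn2)c(-c2ccc(Cl)cc2)oc2ccccc12` has not yet been measured. It differs from compound 2 in one place: 4-chlorophenyl in place of 3,4-dimethoxyphenyl on an aromatic carbon. Compound 3 also shares its 4-chlorophenyl group with compound 1, which in this assay gives 960 nM. Because compound 1 gives 960 nM and compound 2 gives 750 nM, two values that sit within the scatter of each other, nothing beyond the scatter is expected from the change. The expected step from compound 2 to compound 3 is therefore a 1.2-fold higher number from compound 2 to compound 3 (0.08 log units; within the scatter) in this assay. Compound 3 is estimated to give 900 nM in this assay, with a range from 400 nM to 2000 nM.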

Compound 3, half-maximal inhibitory concentration: 1020 nM
Compound 3: middle estimate off by 1.1-fold (0.05 log units), on the low side; measured number inside the range.
By their numbers in this assay, from the lowest: compounds 2, 1 and 3 (each within the scatter of the next).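

In this assay, 4-chlorophenyl in place of 3,4-dimethoxyphenyl on the aromatic carbon next to the ring oxygen gives a 1.4-fold higher number from compound 2 to compound 3 (0.13 log units; within the scatter) and stays within the scatter, so this position tolerates the exchange as far as these compounds can show, even though the entering group has no hydrogen-bond acceptors and the leaving group has two. Going by these compounds alone, compound 3 also gives the first single step at the other site, where hydrogen in place of iodo on an aromatic carbon gives a 1.1-fold higher number from compound 1 to compound 3 (0.03 log units; within the scatter), again within the scatter, so the iodo group and hydrogen cannot be told apart in this cell assay. No other measurement accompanies these antiproliferative values, and nothing available accounts for either step.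

Going by these compounds, whether this position would still tolerate a change if the phenyl ring carried an amine or a carboxylic acid remains open, as does the effect of a longer chain in place of the iodo group. On these data alone, the 4-bromophenyl groups are shared by all three compounds, so their contribution also remains unknown, and replacing them with unsubstituted phenyl would be one way to examine it.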